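The source may report more compounds than this note shows. Statements on the series, on what has been measured and on what is new or still open speak of the compounds shown alone.

Working notes on the series. Compound 1 `CCCCC(=O)N1CCC(N2CCN(C(=O)c3c(NC(=O)NCC)sc4ccccc34)CC2)CC1` carries no result in a functional assay on HepG2 cells (Homo sapiens) for inhibition, read by scintillation counting, with a stated time of 2 h; on this read-out higher numbers stand for weaker inhibition and lower numbers for stronger inhibition: its entry reads "not determined" (no result reported), so there is no number on which compound 1 can be placed. Compound 2 `CCNC(=O)Nc1sc2ccccc2c1C(=O)N1CCN(C2CCN(C(=O)OC(C)(C)C)CC2)CC1` shares the core, and in this assay compound 2 gives 79 nM. Compound 3 `CCNC(=O)Nc1sc2ccccc2c1C(=O)N1CCN(C2CCN(C(=O)NC(C)(C)C)CC2)CC1` is still to be measured in this assay. It arises from compound 1 by one change, ((tert-butyl)amino in place of butyl on a carbonyl carbon). For the measured compounds named here, with compound 1 unmeasured and no step between measured compounds available, the change from compound 1 to compound 3 cannot be sized from the data; the working expectation in this assay is a step of no more than the scatter, in neither direction. Going by the values given here, the only anchor is compound 2, which sits in the same series and gives 79 nM. Compound 3 is accordingly estimated at 70 nM, with a range from 20 nM to 250 nM.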

Compound 3, half-maximal inhibitory concentration: 775 nM
Compound 3: middle estimate off by 11-fold (1.04 log units), on the low side; the whole stated range lies below it.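

With the tert-butyl group held constant, the atom joining it to the carbonyl carbon on the ring amide-type nitrogen is not a silent change: (tert-butyl)amino in place of tert-butoxy gives a 9.8-fold higher number from compound 2 to compound 3 (0.99 log units; beyond the scatter) in this assay, meaning weaker inhibition. For the compounds shown here, this is the first measured step, and it shows that this position responds to a single-atom exchange by more than the scatter. No supporting measurement bears on the reason for this loss.

Steps involving compound 1 cannot be read, so the butylcarbonyl group remains unplaced against both carbamate and urea forms. As far as these compounds go, whether the same loss appears with smaller groups, such as methoxy set against methylamino, or with a cyclohexylamino group on this carbonyl carbon, remains open.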